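Series notes: urea tail replaced by an amide

The compounds below may be only part of what the source reports. "The series", "measured", "known", "first", "only" and "open" are said of these compounds alone.

Compound 1 `COc1cc(-c2nn(-c3ccc(NC(=O)Nc4ccc(Cl)c(C(F)(F)F)c4)cc3)cc2-c2ccncc2)ccc1Cl` and compound 2 `O=C(Nc1ccc(-n2cc(-c3ccncc3)c(-c3ccc(Cl)c(O)c3)n2)cc1)Nc1ccc(Cl)c(C(F)(F)F)c1` share a core and differ only by hydrogen in place of methyl on an oxygen on an aromatic ring. In a functional assay on UACC-257 cells (Homo sapiens) for antiproliferative activity, read by sulforhodamine B assay, with a stated time of 48 h (a higher number here means a weaker inhibitor, a lower number a stronger inhibitor), compound 1 gives 1640 nM and compound 2 gives 1510 nM; the step of a 1.1-fold lower number from compound 1 to compound 2 (0.04 log units; within the scatter) lies within the scatter, so the two numbers cannot be told apart. Of the two numbers, compound 2 carries the smaller one, but the gap to compound 1 is within the scatter and carries no weight.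

Compound 3 `O=C(Nc1ccc(-n2cc(-c3ccncc3)c(-c3ccc(Cl)c(O)c3)n2)cc1)c1ccc(Cl)c(C(F)(F)F)c1` is not yet measured. It differs from compound 2 by 4-chloro-3-(trifluoromethyl)phenyl in place of (4-chloro-3-(trifluoromethyl)phenyl)amino on a carbonyl carbon. No measured step bears on this change: the only step shown, from compound 1 to compound 2, concerns the oxygen on the aromatic ring and leaves the carbonyl untouched. The change removes a hydrogen-bond donor at the carbonyl, and nothing in the two measured compounds shows what that does in this assay. The expectation therefore rests on the change alone; a step beyond the scatter toward a higher number is expected, a 2.3-fold higher number from compound 2 to compound 3 (0.37 log units; beyond the scatter). Compound 3 is expected at 3500 nM, with a range from 1200 nM to 12000 nM.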

Compound 3, half-maximal inhibitory concentration: 2550 nM
Compound 3: the middle estimate sits 1.4-fold (0.14 log units) above what was measured, and the stated range covers the measured number.
By their numbers in this assay, from the lowest: compounds 2, 1 and 3 (each within the scatter of the next).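

In this assay, within the data shown here, the first reading at the carbonyl carbon, 4-chloro-3-(trifluoromethyl)phenyl in place of (4-chloro-3-(trifluoromethyl)phenyl)amino gives a 1.7-fold higher number from compound 2 to compound 3 (0.23 log units; within the scatter), so the urea and the amide tail cannot be told apart here. The earlier pair spoke only to the oxygen on the aromatic ring, whereas this pair shows that, with that oxygen carrying hydrogen, the amino nitrogen and its hydrogen-bond donor can be lost without a step beyond the scatter, although this rests on one pair in one cell line. Nothing available accounts for this reading or shows what lies behind it.

Among these compounds, whether the amide tail reads the same with the methyl on that oxygen remains open, as this change has been seen only on the hydroxyl form of the core. Also open, on these data alone, is how other links on the carbonyl carbon would read in this assay, such as an oxygen atom as in a carbamate or a methylene carbon, and whether any replacement at this position would move the number beyond the scatter.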